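This account rests on a few compounds, and the source may have more. Where it says the series, first, only, none or still open, it means among the compounds named here.

Among the measured compounds shown here, the series is read in a functional assay on NCI-H460 cells (Homo sapiens) for inhibition, read by MTT assay, with a stated time of 24 h, tested at 0.1 ug/mL (on this read-out higher numbers stand for more inhibition of growth at the one concentration tested and lower numbers for less inhibition of growth), and only three compounds have results so far. Compound 3 (`O=C(CCCCC(S)CCS)Nc1ccc(Cl)cc1`) is reported as "not active" (no number reported) with no single number attached, so it has no exact place on the scale. Compound 1 (`O=C(O)CCCCC(CCSC(=O)c1ccccc1)SC(=O)c1ccccc1`) is the one further entry of this kind and also reads "not active" (no number reported) in this assay without a figure. For the measured compounds named here, compound 2 (`O=C(CCCCC1CCSS1)Nc1ccc(Br)cn1`) gives 9% and is the only entry with a number.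

Compound 4 (`COc1ccc(NC(=O)CCCCC(S)CCS)cc1`) has not yet been measured. The structural change is methoxy in place of chloro on an aromatic carbon and amounts to methoxy in place of chloro on an aromatic carbon. Going by the values given here, no measured pair differs in one place only, so the data give no direct gauge of what such a change does in this assay at the one concentration tested. Among the compounds with values here, no step beyond the usual scatter is expected in either direction, an expectation that rests on compound 3 at "not active" (no number reported) and compound 2 at 9% as the only nearby readings. A report without a number is also a real possibility for this compound. In this assay the estimate for compound 4 is an expected 7% with a likely range of 0% to 20% as the estimated spread.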

Compound 4, percent growth inhibition at one concentration: 5.69%
The estimate for compound 4 lay 1.3 percentage points above the measured number; the range from low to high includes it.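

In this assay, among the compounds shown here, compound 3 is reported without a number, so no step from it to compound 4 at 5.69% can be read. The compounds shown leave open what methoxy in place of chloro does in this assay at the one concentration tested. No evidence bearing on this result is available.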